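The source may hold more compounds than are shown below. What is called first, only, known or untested is meant among the compounds shown, and "the series" means these compounds.

Compound 1 `COc1nc(-c2ccccc2F)ccc1[C@@H](c1ccccc1)[C@@](O)(CCN(C)C)c1cccc2ccccc12` gives "nd" (no result reported) in a toxicity assay on HeLa cells (Homo sapiens) for cytotoxicity (on this read-out higher numbers stand for lower toxicity in this test and lower numbers for higher toxicity in this test), that is, no result. Compound 2 `COc1nc(-c2ccsc2)ccc1[C@@H](c1ccccc1)[C@@](O)(CCN(C)C)c1cccc2ccccc12` gives > 64 ug/mL in this assay, which is a limit rather than a number. Compound 3 `COc1nc(-c2ccncc2)ccc1[C@@H](c1ccccc1)[C@@](O)(CCN(C)C)c1cccc2ccccc12` gives 9.6 ug/mL in this assay.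

Among the compounds with values here, compound 3 therefore holds the only single number among the three. Within the data shown here, the one measured step, an at least 6.6-fold lower number from compound 2 to compound 3 (0.82 log units; beyond the scatter), went with pyridin-4-yl in place of thiophen-3-yl on an aromatic carbon. Compound 4 `COc1nc(-c2ccc(OC(F)(F)F)cc2)ccc1[C@@H](c1ccccc1)[C@@](O)(CCN(C)C)c1cccc2ccccc12` differs from compound 3 by 4-(trifluoromethoxy)phenyl in place of pyridin-4-yl on an aromatic carbon. Because pyridin-4-yl leaves again, for compound 4 the number is expected to rise by a 4.2-fold higher number from compound 3 to compound 4 (0.62 log units; beyond the scatter), back toward the limit (the limit of > 64 ug/mL in this assay, at which 1 of the 3 values shown sits). Compound 4 is thus estimated at 40 ug/mL, with a range from 12 ug/mL to 100 ug/mL.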

Compound 4, half-maximal cytotoxic concentration: > 64 ug/mL
Compound 4 was reported as a limit; the forecaster's own chance of this, stated with the estimate: 50%; at least 1.6-fold (0.20 log units) between middle value and limit.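

Placing 4-(trifluoromethoxy)phenyl instead of pyridin-4-yl next to the ring nitrogen gives an at least 6.6-fold higher number from compound 3 to compound 4 (0.82 log units; beyond the scatter) in this assay, so a second replacement, this one with an aromatic ring of carbon only, also moves away from the number of compound 3. The value of compound 4 is a limit, and the step between compound 2 and compound 4 cannot be read. Among the compounds with a result, only compound 3 gives a single number, and the other two share one limit: the limit of > 64 ug/mL in this assay, at which 2 of the 4 values shown sit.

On these data alone, it remains open whether the ring nitrogen of pyridin-4-yl itself goes with the lower number. Plain phenyl or pyridin-3-yl at this position would bear on that question.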